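A few compounds are considered here, and "the series" means these few. Any claim that something is new, unique, unknown or untested is made for them only; others in the source may bear on it.

Measured so far in a functional assay on MCF7 cells (Homo sapiens) for antiproliferative activity, read by MTT assay, with a stated time of 48 h; on this read-out higher numbers stand for weaker inhibition and lower numbers for stronger inhibition:

- compound 1 `COc1cccc(C(=O)Nc2nnc(/C=C/c3cc(OC)c(OC)c(OC)c3Br)s2)c1` gives 170 nM
- compound 2 `COc1ccc(C(=O)Nc2nnc(/C=C/c3cc(OC)c(OC)c(OC)c3Br)s2)cc1` gives 560 nM

Of these two, compound 2 stands higher, at 560 nM, so it is the weaker inhibitor. Compound 3 `COc1cc(/C=C/c2nnc(NC(=O)c3ccccc3Br)s2)c(Br)c(OC)c1OC` is the next to be tested, with 2-bromophenyl in place of 4-methoxyphenyl on a carbonyl carbon. Going by the values given here, one measured step bears on this place: a 3.3-fold higher number from compound 1 to compound 2 (0.52 log units; beyond the scatter). Among the compounds with values here, that modest step exchanges 3-methoxyphenyl for 4-methoxyphenyl, and no measured step introduces 2-bromophenyl. Within the data shown here, it therefore shows only that a change here can move the number, and it gives no firm direction. Among the measured compounds shown here, a small shift towards a lower number is expected, no larger than that step. The expected change is a 1.4-fold lower number from compound 2 to compound 3 (0.15 log units; within the scatter). For compound 3 the estimated value is 400 nM, with an expected range from 120 nM to 1300 nM.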

Compound 3, half-maximal inhibitory concentration: 370 nM
Compound 3: the middle estimate sits 1.1-fold (0.03 log units) above what was measured; low and high end bracket the measured number.
By their numbers in this assay, from the lowest: compound 1; then compounds 3 and 2 (each within the scatter of the next).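

In this assay, putting 2-bromophenyl in place of 4-methoxyphenyl on the carbonyl carbon gives a 1.5-fold lower number from compound 2 to compound 3 (0.18 log units; within the scatter) and so leaves the two compounds indistinguishable, showing that this position tolerates a bromine-bearing ring as well as the 4-methoxyphenyl ring. Set against 3-methoxyphenyl, the same group gives a 2.2-fold higher number from compound 1 to compound 3 (0.34 log units; beyond the scatter) and this modest step means that compound 1, whose steps to both others lie beyond the scatter, remains the strongest inhibitor of the three. Nothing available explains these differences in terms of measured properties.

From the compounds shown here alone, it remains open whether the advantage of compound 1 belongs to the methoxy group or to where that group sits on the ring. Unsubstituted phenyl, 3-bromophenyl, or a ring carrying an amine or a carboxylic acid at this place could settle how far this position can be pushed.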